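The source may hold more compounds than are shown below. What is called first, only, known or untested is meant among the compounds shown, and "the series" means these compounds.

Measured compounds:
compound 1 `CCC(c1ccccc1)c1nc(-c2ccc(Cl)cc2)c(CC(=O)O)s1`, 190 nM
compound 2 `O=C(O)Cc1sc(CSc2ccccc2)nc1-c1ccc(Cl)cc1`, 250 nM
compound 3 `O=C(O)Cc1sc(C(Cc2ccccc2)c2ccccc2)nc1-c1ccc(Cl)cc1`, 56 nM

All three numbers come from an in vitro assay on HEK385-7 cells for displacement of a labelled ligand from prostaglandin D2 receptor 2 (Homo sapiens); on this read-out higher numbers stand for weaker inhibition and lower numbers for stronger inhibition. Compound 3 stands lowest of the three; its nearest neighbour is compound 1, its furthest compound 2, and both gaps fall beyond the scatter. Within the data shown here, the only single-point step among the measured compounds is a 3.4-fold lower number from compound 1 to compound 3 (0.53 log units; beyond the scatter), a phenyl entering in place of methyl on a saturated chain carbon two bonds along the chain from two aromatic carbons, a modest gain.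

Compound 4 `O=C(O)Cc1sc(C(c2ccccc2)c2ccc(Cl)cc2)nc1-c1ccc(Cl)cc1` differs from compound 3 by 4-chlorophenyl in place of benzyl on a saturated chain carbon bound to two aromatic carbons. Among the measured compounds shown here, no measured step touches this position directly: the measured step sits one bond further out along the chain, and compound 2 differs from compound 3 in more than one place, so only its two values can be compared, and they show compound 2 well above compound 3. The change in compound 4 keeps the heavy-atom count of the group and keeps a single carbon ring, which argues against a large shift in this assay; the measured gain suggests the position tolerates an aromatic ring. The step of a 1.2-fold lower number from compound 3 to compound 4 (0.09 log units; within the scatter) is therefore expected to stay within the scatter. Compound 4 is estimated at 45 nM, with a range from 15 nM to 140 nM.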

Compound 4, half-maximal inhibitory concentration: 45 nM
Compound 4: middle estimate and measured number agree at the digits printed, within the range that was stated.
By their numbers in this assay, from the lowest: compounds 4 and 3 (each within the scatter of the next); then compounds 1 and 2 (each within the scatter of the next).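

In this assay the exchange of benzyl for 4-chlorophenyl on a saturated chain carbon bound to two aromatic carbons gives a 1.2-fold lower number from compound 3 to compound 4 (0.09 log units; within the scatter) and so leaves the number unchanged within the scatter, which shows that this position accepts two differently built aromatic groups of equal heavy-atom count, one of them carrying chlorine. The comparison with the ethyl group of compound 1 gives a 4.2-fold lower number from compound 1 to compound 4 (0.63 log units; beyond the scatter) and, read beside a 3.4-fold lower number from compound 1 to compound 3 (0.53 log units; beyond the scatter) as well, shows that the lower number on this carbon is reached with either aromatic group and does not depend on the benzyl form alone, though this holds for these three compounds only. Nothing on hand explains the size of either step.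

The step exchanges the whole group, so the contribution of the chlorine cannot be separated from that of the chain carbon lost with the benzyl group. Also open, from the compounds shown here alone, is how this position responds to a ring bearing a hydroxyl or an amine, or to a pyridine ring in place of 4-chlorophenyl.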